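Chloro to cyano on the shared core

The compounds below may be only part of what the source reports. "The series", "measured", "known", "first", "only" and "open" are said of these compounds alone.

Measured so far:
Compound 1 `CC/C(=C(/c1ccc(/C=C/C(=O)O)cc1)c1cc2ccccc2[nH]1)c1ccccc1C` gives 33 nM in a functional assay on MCF7 cells (Homo sapiens) for inhibition; a lower number here means a stronger inhibitor, a higher number a weaker inhibitor.
Compound 2 `CC/C(=C(/c1ccc(/C=C/C(=O)O)cc1)c1cc2ccccc2[nH]1)c1ccccc1Cl` gives 42 nM in this assay.

For the measured compounds named here, compound 2 carries the higher of the two numbers, yet its only neighbour, compound 1, sits within the scatter of it. Compound 3 `CC/C(=C(/c1ccc(/C=C/C(=O)O)cc1)c1cc2ccccc2[nH]1)c1ccccc1C#N` differs from compound 2 by cyano in place of chloro on an aromatic carbon. Going by the values given here, the one measured step that bears on this position is a 1.3-fold higher number from compound 1 to compound 2 (0.10 log units; within the scatter), a small move. A step of similar size, within the scatter, is therefore expected in this assay, a 1.2-fold higher number from compound 2 to compound 3 (0.08 log units; within the scatter). Compound 3 is estimated at 50 nM, with a range of 20 nM to 125 nM.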

Compound 3, half-maximal inhibitory concentration: 9 nM
The estimate for compound 3 lay 5.6-fold (0.74 log units) above the measured number; measured number outside the range, below it.
By their numbers in this assay, from the lowest: compound 3; then compounds 1 and 2 (each within the scatter of the next).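

In this assay this position proves sensitive to the group it carries, which the methyl and chloro pair could not show: cyano gives a 4.7-fold lower number from compound 2 to compound 3 (0.67 log units; beyond the scatter) and a 3.7-fold lower number from compound 1 to compound 3 (0.56 log units; beyond the scatter). The nitrile therefore separates from both earlier groups, which remain within the scatter of each other. Nothing available accounts for this separation.

As far as these compounds go, it remains open whether the lower number is particular to the nitrile or is shared by other groups here, such as trifluoromethyl, methoxy or a primary amide. From the compounds shown here alone, the effect of moving the nitrile elsewhere on this ring also remains open.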